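The compounds below may be only part of what the source reports. "The series", "measured", "known", "first", "only" and "open" are said of these compounds alone.

The series shares one core, varied only at the group on the double-bonded chain carbon. Compound 1 `COc1cc2nc(/C=C/c3ccccn3)nc(N3CCC(CCNS(N)(=O)=O)CC3)c2cc1OC` gives 71 nM in an assay on cells for inhibition of Ectonucleotide pyrophosphatase/phosphodiesterase family member 1 (Homo sapiens), with a stated time of 60 min; on this read-out lower numbers stand for stronger inhibition and higher numbers for weaker inhibition. Compound 2 `COc1cc2nc(/C=C/c3ccccc3F)nc(N3CCC(CCNS(N)(=O)=O)CC3)c2cc1OC` gives 211 nM in this assay, and compound 3 `COc1cc2nc(/C=C/c3cccc(F)c3)nc(N3CCC(CCNS(N)(=O)=O)CC3)c2cc1OC` gives 3580 nM. Compound 3 therefore stands with the highest number of the three: the move from compound 2 to compound 3 reads a 17-fold higher number from compound 2 to compound 3 (1.23 log units; beyond the scatter), and the move from compound 1 to compound 3 reads a 50-fold higher number from compound 1 to compound 3 (1.70 log units; beyond the scatter), both beyond the scatter. The smaller step, a 3.0-fold higher number from compound 1 to compound 2 (0.47 log units; beyond the scatter), shows that the 2-fluorophenyl compound stays much closer to compound 1 than the 3-fluorophenyl compound does.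

Compound 4 `COc1ccccc1/C=C/c1nc(N2CCC(CCNS(N)(=O)=O)CC2)c2cc(OC)c(OC)cc2n1` differs from compound 3 in one place: 2-methoxyphenyl in place of 3-fluorophenyl on a double-bonded chain carbon bound to a double-bonded chain carbon. The step that bears most directly on it is a 17-fold higher number from compound 2 to compound 3 (1.23 log units; beyond the scatter), since compound 2 also carries a substituent at the 2-position of the phenyl and its number is far lower than that of compound 3. On that basis compound 4 is expected to give a markedly lower number than compound 3, a step of a 12-fold lower number from compound 3 to compound 4 (1.08 log units; beyond the scatter), though a methoxy group is not a fluorine and no direct comparison of the two exists here. Compound 4 is accordingly estimated at 300 nM, within a range from 80 nM to 1200 nM.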

Compound 4, inhibition constant: 302 nM
Compound 4: middle estimate off by 1.0-fold (0.00 log units), on the low side, and the stated range covers the measured number.
By their numbers in this assay, from the lowest: compound 1; then compounds 2 and 4 (each within the scatter of the next); then compound 3.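

Exchanging fluoro for methoxy on the aromatic carbon leaves the two compounds indistinguishable in this assay, with a 1.4-fold higher number from compound 2 to compound 4 (0.16 log units; within the scatter), so the number at this place does not separate these two groups. The 2-methoxyphenyl group also stands well apart from the 3-fluorophenyl group, with a 12-fold lower number from compound 3 to compound 4 (1.07 log units; beyond the scatter), which gives a second case, after the 2-fluorophenyl group, of a substituted phenyl with a far lower number than the 3-fluorophenyl compound, although this step changes the group as well as where it sits on the ring. Neither of the two groups matches pyridin-2-yl, as a 4.3-fold higher number from compound 1 to compound 4 (0.63 log units; beyond the scatter) shows, so compound 1 keeps the lowest number of the four, and the methoxy result extends that gap to a second substituted phenyl.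

Nothing available here accounts for any of these differences. The compounds shown leave open how unsubstituted phenyl, 3-methoxyphenyl, 2-aminophenyl or 2-carboxyphenyl would read at this place, and 3-methoxyphenyl in particular would show whether the high number of compound 3 goes with the fluoro group or with where it sits.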